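Thiazolyl for acetyl on the sulfonamide nitrogen

The compounds below may be only part of what the source reports. "The series", "measured", "known", "first", "only" and "open" are said of these compounds alone.

Among the measured compounds shown here, compound 2 `CC(=O)NS(=O)(=O)c1ccc(N/C(S)=N\c2ccnc3cc(C(F)(F)F)ccc23)cc1` is the only entry with a number in a functional assay on HepG2 cells (Homo sapiens) for antiproliferative activity, read by sulforhodamine B assay, with a stated time of 48 h (on this read-out lower numbers stand for stronger inhibition and higher numbers for weaker inhibition), where compound 2 gives 28400 nM. Compound 1 `O=C(Nc1ccccc1)Nc1ccc(S(=O)(=O)Nc2ccnc3cc(C(F)(F)F)ccc23)cc1` is reported in this assay as "not active" (no number reported), without a number. Compound 3 `O=S(=O)(Nc1nccs1)c1ccc(N/C(S)=N\c2ccnc3cc(C(F)(F)F)ccc23)cc1` follows from compound 2 by the change (1,3-thiazol-2-yl in place of acetyl on a sulfonamide nitrogen), a 1,3-thiazol-2-yl in place of acetyl on a sulfonamide nitrogen whose other neighbour is the sulfonyl sulfur. For the measured compounds named here, no step between measured compounds exists to gauge this change. The step expected from it is a 1.3-fold lower number from compound 2 to compound 3 (0.11 log units; within the scatter), not beyond the usual scatter and in no fixed direction. Compound 3 is estimated at 22000 nM, between 7000 nM and 70000 nM.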

Compound 3, half-maximal inhibitory concentration: 28200 nM
Compound 3: middle estimate off by 1.3-fold (0.11 log units), on the low side; the range from low to high includes it.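

In this assay the change to 1,3-thiazol-2-yl in place of acetyl on a sulfonamide nitrogen gives a 1.0-fold lower number from compound 2 to compound 3 (0.00 log units; within the scatter) and so leaves the two compounds indistinguishable. For this pair, the sulfonamide nitrogen carries a five-membered aromatic ring as well as an acetyl group with no measurable difference in the read-out. No measured evidence accounts for this match.

Still open, as far as these compounds go, is whether a simple alkyl chain, a longer acyl chain or a phenyl group on this nitrogen would stay at the same level. A carboxylic acid or an amine carried on that substituent is equally untested by the compounds shown.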